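Swapping the piperazine of compound 1 for a carbonyl-linked group

The source may report more compounds than this note shows. Statements on the series, on what has been measured and on what is new or still open speak of the compounds shown alone.

In a physicochemical assay for solubility, read by HPLC, using the shake flask method, in phosphate buffer, measured as kinetic solubility, with a stated time of 20 h, at pH 6.5 (a higher number here means a more soluble compound, a lower number a less soluble compound), compound 1 (`Fc1ccc(Nc2cc3[nH]c(Nc4cc(N5CCNCC5)ccn4)nc3cn2)cc1C(F)(F)F`) gives 95000 nM and lies within the scatter of compound 2 (`Fc1ccc(Nc2cc3[nH]c(Nc4ccc(N5CCN(CC6CC6)CC5)cn4)nc3cn2)cc1C(F)(F)F`) at 75000 nM in the same measurement. These two compounds share the upper end of the three numbers available. Compound 3 (`CC(C)CN1CCN(c2ccc(Nc3nc4cnc(NC5CCC(F)(F)CC5)cc4[nH]3)nc2)CC1`) gives 10000 nM and falls beyond the scatter below compound 1.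

Compound 4 (`C[C@@H]1CN(C(=O)c2ccnc(Nc3nc4cnc(Nc5ccc(F)c(C(F)(F)F)c5)cc4[nH]3)c2)C[C@H](C)N1`) keeps the core of compound 1 and alters one group, with (3,5-dimethylpiperazin-1-yl)carbonyl in place of piperazin-1-yl on an aromatic carbon. Among the compounds with values here, no two measured compounds differ in only one place, so nothing measured so far isolates this change and any forecast remains loose. A shift towards a lower number is expected, but one that stays within the scatter, and the estimated step is small (a 1.9-fold lower number from compound 1 to compound 4 (0.28 log units; within the scatter)). In this assay compound 4 is expected to give about 50000 nM (estimated range 15000 nM to 120000 nM).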

Compound 4, solubility: 200000 nM
Compound 4: the middle estimate sits 4.0-fold (0.60 log units) below what was measured; the measured number lies above the stated range.
By their numbers in this assay, from the lowest: compound 3; then compounds 2 and 1 (each within the scatter of the next); then compound 4.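

In this assay, within the data shown here, the pair of compound 1 and compound 4 gives the first reading of a single change at this position, on an aromatic carbon opposite the ring nitrogen: a 2.1-fold higher number from compound 1 to compound 4 (0.32 log units; beyond the scatter), a modest step. Replacing piperazin-1-yl with (3,5-dimethylpiperazin-1-yl)carbonyl, which brings in a carbonyl and two defined stereocentres, therefore raises the number here rather than lowering it. Nothing measured here bears on why the number rises.

The carbonyl and the two methyl groups enter together, so the compounds shown leave open how much of the step belongs to each; a piperazin-1-ylcarbonyl group without the methyl groups would separate them. Also open, on these data alone, is whether an open-chain amine on the same carbonyl would give a similar number.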